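Trimming one methoxy arm on the amino side chain

A few compounds are considered here, and "the series" means these few. Any claim that something is new, unique, unknown or untested is made for them only; others in the source may bear on it.

Measured compounds:
compound 1, `CCCCN(CC)c1nc(C)nc2c1nnn2-c1c(C)cc(C)nc1C`, 65 nM
compound 2, `COCC(COC)Nc1nc(C)nc2c1nnn2-c1ccc(C(C)C)cc1Br`, 10.3 nM

In an in vitro assay on 293-EBNA cells for binding affinity to corticotropin-releasing factor receptor 1 (Homo sapiens) (on this read-out higher numbers stand for weaker inhibition and lower numbers for stronger inhibition), compound 2 shows the lower of the two numbers, while compound 1 sits well outside the scatter at the higher number. Compound 3, `COCC(C)(C)Nc1nc(C)nc2c1nnn2-c1ccc(C(C)C)cc1Br`, is not yet measured. It differs from compound 2 by 1-(methoxymethyl)-1-methylethyl in place of 2-methoxy-1-(methoxymethyl)ethyl on a nitrogen on an aromatic ring; the two structures are otherwise the same. Among the compounds with values here, no measured pair isolates this change, so the expectation rests on compound 2 alone. For compound 3 a step of a 1.5-fold higher number from compound 2 to compound 3 (0.16 log units; within the scatter) is expected, with any loss of potency likely staying small. Compound 3 is estimated at 15 nM, in the range 5 nM to 50 nM.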

Compound 3, inhibition constant: 195 nM
Compound 3: middle estimate off by 13-fold (1.11 log units), on the low side, and the stated range ends below it.
By their numbers in this assay, from the lowest: compound 2; then compound 1; then compound 3.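

In this assay the amino side chain turns out to be sensitive to a small edit: 1-(methoxymethyl)-1-methylethyl in place of 2-methoxy-1-(methoxymethyl)ethyl gives a 19-fold higher number from compound 2 to compound 3 (1.28 log units; beyond the scatter) and counts as a large step. The entering group has one hydrogen-bond acceptor fewer and one heavy atom fewer, but nothing available explains the loss. Still open, going by these compounds, is whether losing the methoxy arm or gaining the methyl matters more. A hydroxymethyl or ethoxymethyl arm in that place would help separate the two.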